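Benzyl in Place of Phenyl on the Distal Carbonyl

The source may hold more compounds than are shown below. What is called first, only, known or untested is meant among the compounds shown, and "the series" means these compounds.

Compound 1 `O=C(O)c1ccc(C(=O)c2ccc(C(=O)c3ccccc3)cc2)cc1`: 40 nM
Compound 2 `O=C(O)c1ccc(C(=O)c2ccc(-c3ccc(Cl)cc3Cl)cc2)cc1`: 85 nM

In an assay on CHO cells for inhibition of 3-oxo-5-alpha-steroid 4-dehydrogenase 2 (Homo sapiens) (a higher number here means a weaker inhibitor, a lower number a stronger inhibitor), compound 1 gives the lowest of the two numbers; its nearest neighbour is compound 2, and the step of a 2.1-fold higher number from compound 1 to compound 2 (0.33 log units; beyond the scatter) is modest. Compound 3 `O=C(O)c1ccc(C(=O)c2ccc(C(=O)Cc3ccccc3)cc2)cc1` differs from compound 1 by benzyl in place of phenyl on a carbonyl carbon. Among the measured compounds shown here, no measured step alters that carbonyl carbon, so only the modest step of a 2.1-fold higher number from compound 1 to compound 2 (0.33 log units; beyond the scatter), which reworks the same end of the molecule more drastically, gives any guide. A small change of this kind is expected to leave the number close to that of compound 1, at most a slight weakening, so compound 3 is estimated at 60 nM (range 25 nM to 150 nM), a step of a 1.5-fold higher number from compound 1 to compound 3 (0.18 log units; within the scatter).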

Compound 3, inhibition constant: 40 nM
For compound 3 the middle estimate is 1.5-fold (0.18 log units) above the measured one; low and high end bracket the measured number.
By their numbers in this assay, from the lowest: compounds 1 and 3 (each within the scatter of the next); then compound 2.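

In this assay, among the compounds shown here, the change to benzyl on the carbonyl carbon gives no change at the digits printed from compound 1 to compound 3 (within the scatter), the first reading of a change at this carbon itself, since the earlier step replaced the whole benzoyl group. The number at this position therefore holds with benzyl as it does with phenyl, at least for this one pair. Nothing available explains this result.

From the compounds shown here alone, whether the number would also hold with a longer chain such as phenethyl, or with an amine on this carbonyl carbon, remains open.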